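The compounds below may be only part of what the source reports. "The series", "measured", "known", "first", "only" and "open" are said of these compounds alone.

Measured compounds in a functional assay on MCF7 cells (Homo sapiens) for inhibition, read by MTT assay, with a stated time of 72 h, tested at 10 uM; on this read-out higher numbers stand for more inhibition at the one concentration tested (going by the name of the read-out) and lower numbers for less inhibition:
compound 1 `CCOC(=O)C1=C(Nc2ccccc2)S/C(=C\c2ccccc2)C1=O` gives 23.6%
compound 2 `CCOC(=O)C1=C(Nc2ccccc2)S/C(=C\c2ccc(OC)cc2)C1=O` gives 14.7%
compound 3 `CCOC(=O)C1=C(Nc2ccccc2)S/C(=C\c2ccc([N+](=O)[O-])c(O)c2)C1=O` gives 41.5%

Compound 2 stands lowest of the three numbers; the step of a number 8.9 percentage points lower from compound 1 to compound 2 (within the scatter) is within the scatter, so compound 1 and compound 2 cannot be ordered, while compound 3 lies beyond the scatter above compound 2. The next compound is compound 4 `CCOC(=O)C1=C(Nc2ccccc2)S/C(=C\c2ccc(C(=O)O)cc2)C1=O`, reached by carboxy in place of methoxy on an aromatic carbon. Among the measured compounds shown here, the only measured step at the same place is a number 8.9 percentage points lower from compound 1 to compound 2 (within the scatter), which lay within the scatter; no measured step puts a carboxy into the series, and the higher number of compound 3 comes with a different change. The step of a number 6.3 percentage points higher from compound 2 to compound 4 (within the scatter) is therefore expected to stay within the scatter. Compound 4 is estimated at 21%, in the range 6% to 38%.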

Compound 4, a percentage reported as inhibition, at one concentration (the size of the read-out at that concentration, not a potency): < 10%
Compound 4 was reported as a limit; the forecaster's own chance of this, stated with the estimate: 2%; at least 11 percentage points between middle value and limit.
By their numbers in this assay, from the lowest: compounds 2 and 1 (each within the scatter of the next); then compound 3. At a limit, below all of these: compound 4.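

In this assay compound 4 is reported as a limit, the only one in the series: the limit of < 10% in this assay, at which 1 of the 4 values shown sits.
Carboxy in place of hydrogen gives the first step at this position to clear the scatter: a number at least 13.6 percentage points lower from compound 1 to compound 4 (beyond the scatter). Carboxy in place of methoxy gives a number at least 4.7 percentage points lower from compound 2 to compound 4 (that floor lies within the scatter), so 4-methoxyphenyl and 4-carboxyphenyl cannot be ordered on this read-out.

Open, from the compounds shown here alone, is how an amine or a methyl ester would read at the same place on the aromatic ring. Also open, going by these compounds, is whether a hydroxy alone or a nitro alone would carry the reading of compound 3, 41.5%.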